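A few compounds are considered here, and "the series" means these few. Any claim that something is new, unique, unknown or untested is made for them only; others in the source may bear on it.

Working notes on the series. Of the compounds shown here, two have been measured in an assay on HEK293 cells for inhibition of Voltage-dependent T-type calcium channel subunit alpha-1G (Homo sapiens), read by fluorescence, tested at 10 uM; a lower number here means less inhibition, a higher number more inhibition at the concentration tested (going by the name of the read-out). Compound 1 `CCCc1nc(-c2ccccc2)c(CNCCN2CCN(c3ccccc3C(F)(F)F)CC2)o1` gives 54.6%, and compound 2 `CCCc1nc(-c2ccccc2)c(CNCCN2CCN(c3cccc(C)c3C)CC2)o1` gives 66.7%. Among the compounds with values here, compound 2 thus stands highest of the two numbers, with compound 1 as its only neighbour. Within the data shown here, the single measured step, a number 12.1 percentage points higher from compound 1 to compound 2 (beyond the scatter), lies beyond the scatter and is modest in size; it arises from exchanging the group on the amine nitrogen in a ring.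

Compound 3 `CCCc1nc(-c2ccccc2)c(CNCCN2CCN(c3cccc(Cl)c3)CC2)o1` has not been measured. It differs from compound 2 at that same ring nitrogen: 3-chlorophenyl in place of 2,3-dimethylphenyl on an amine nitrogen in a ring. Among the measured compounds shown here, the one step that bears on this change is a number 12.1 percentage points higher from compound 1 to compound 2 (beyond the scatter), since it too exchanges the group on the amine nitrogen in a ring. It shows that such an exchange moves the read-out by a modest amount, but the 3-chlorophenyl group is neither of the two groups already measured, so no direction can be read from it. The expected step is therefore small and of uncertain sign, a number 8.7 percentage points lower from compound 2 to compound 3 (within the scatter), possibly within the scatter. Compound 3 is estimated to give 58% in this assay, with a range from 38% to 76%.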

Compound 3, a percentage reported as inhibition, at one concentration (the size of the read-out at that concentration, not a potency): 51.2%
For compound 3 the middle estimate is 6.8 percentage points above the measured one; low and high end bracket the measured number.
By their numbers in this assay, from the lowest: compounds 3 and 1 (each within the scatter of the next); then compound 2.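

Three aryl groups now stand on the amine nitrogen in a ring, and in this assay the change to 3-chlorophenyl gives a number 15.5 percentage points lower from compound 2 to compound 3 (beyond the scatter), so 2,3-dimethylphenyl is set apart from both other groups by steps beyond the scatter. The other new step, a number 3.4 percentage points lower from compound 1 to compound 3 (within the scatter), lies within the scatter, so 3-chlorophenyl and 2-(trifluoromethyl)phenyl cannot be told apart in this read-out even though they are different groups. No independent measurement on hand explains either step.

As far as these compounds go, it remains open whether the separation of compound 2 depends on both methyl groups together or on one of them alone, a question that 2-methylphenyl and 3-methylphenyl on the same nitrogen would address. From the compounds shown here alone, the three compounds also share the propyl chain and the rest of the core, so the response of this read-out to a shorter chain such as ethyl, and whether the steps seen here at a single concentration would carry over to other changes on the core, also stay open.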